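Swapping isopropyl for an aromatic group on the carbonyl

The compounds below may be only part of what the source reports. "The series", "measured", "known", "first", "only" and "open" are said of these compounds alone.

Compound 1 (`COc1ccc(/C=C/C(=O)c2ccc(OC)c3c2OC(C)(C)C=C3)cc1O`) carries a free hydrogen on an aromatic-ring oxygen, where compound 2 (`CCC(=O)Oc1cc(/C=C/C(=O)c2ccc(OC)c3c2OC(C)(C)C=C3)ccc1OC`) has propanoyl and compound 3 (`COc1ccc(/C=C/C(=O)c2ccc(OC)c3c2OC(C)(C)C=C3)cc1OC(=O)C(C)C`) has isopropylcarbonyl. In an ADME assay on L02 cells (Homo sapiens) for cytotoxicity, read by MTT assay (a higher number here means a weaker inhibitor, a lower number a stronger inhibitor), compound 1 gives > 10000 nM, a limit. Compound 2 gives > 10000 nM, also a limit. Compound 3 gives > 10000 nM, again a limit. Compound 3 therefore shares (the limit of > 10000 nM in this assay, at which 3 of the 3 values shown sit).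

Compound 4 (`COc1cccc(C(=O)Oc2cc(/C=C/C(=O)c3ccc(OC)c4c3OC(C)(C)C=C4)ccc2OC)c1`) has 3-methoxyphenyl in place of isopropyl on a carbonyl carbon. The closest evidence is a step that the two limits leave unreadable from compound 2 to compound 3, alongside a step that the two limits leave unreadable from compound 1 to compound 2 and a step that the two limits leave unreadable from compound 1 to compound 3, so no size carries over. The expected change, a step that the limit leaves unreadable from compound 3 to compound 4, is an estimate with no firm direction. Compound 4 is expected near 15000 nM, with an estimated range of 6000 nM to 40000 nM, and probably only as a limit.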

Compound 4, half-maximal inhibitory concentration: > 10000 nM
Compound 4: only a limit was reported; the forecaster's own chance of this, stated with the estimate: 80%; the middle value does not contradict the limit.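

Compound 4 sits at the same limit as compound 1, compound 2 and compound 3, so no step among these compounds can be read: the limit of > 10000 nM in this assay, at which 4 of the 4 values shown sit.

Going by these compounds, how strongly any of the four acts in this assay, and whether the group on the carbonyl matters there, stays open.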